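The compounds below may be only part of what the source reports. "The series", "measured", "known", "first", "only" and "open" are said of these compounds alone.

Compound 1 `C/C(=N\NC(=O)c1cccc(S(=O)(=O)N2CCOCC2)c1)c1cccc(O)c1` gives in a functional assay on MGC-803 cells (Homo sapiens) for antiproliferative activity, read by MTT assay, with a stated time of 72 h (a higher number here means a weaker inhibitor, a lower number a stronger inhibitor), only the assay limit > 100000 nM.
Compound 2 `C/C(=N\NC(=O)c1cccc(S(=O)(=O)N2CCOCC2)c1)c1cc(O)ccc1O` gives in this assay 9090 nM.
Compound 3 `O=C(N/N=C/c1ccccn1)c1cccc(S(=O)(=O)N2CCOCC2)c1` gives in this assay 81700 nM.

Of the two compounds with a number in this assay, compound 3 stands highest, so it is the weaker of the pair. Its nearest neighbour is compound 2, whose number is lower by a margin beyond the scatter. Compound 1 reaches only the limit of this assay (the limit of > 100000 nM in this assay, at which 1 of the 3 values shown sits), so it cannot be placed relative to the others beyond that.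

Compound 4 `COc1ccc(/C=N/NC(=O)c2cccc(S(=O)(=O)N3CCOCC3)c2)c(O)c1` differs from compound 3 in one place: 2-hydroxy-4-methoxyphenyl in place of pyridin-2-yl on a carbon with a double bond to nitrogen. Among the measured compounds shown here, only one measured step speaks to this change, namely an at least 11-fold lower number from compound 1 to compound 2 (1.04 log units; beyond the scatter), which shows that a hydroxy entering an aromatic carbon on the ring borne by the carbon with a double bond to nitrogen lowered the number strongly. The ring entering compound 4 also carries a hydroxy, while the pyridin-2-yl it replaces carries none. For the measured compounds named here, compound 4 is therefore expected to give a lower number than compound 3, beyond the scatter, though the methoxy has no measured precedent here. The step from compound 3 to compound 4 is expected to be a 5.4-fold lower number from compound 3 to compound 4 (0.74 log units; beyond the scatter). Compound 4 is estimated at 15000 nM, within a range from 4000 nM to 60000 nM.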

Compound 4, half-maximal inhibitory concentration: 2070 nM
Estimate against measurement, compound 4: 7.2-fold (0.86 log units) above; measured number below the stated range.
By their numbers in this assay, from the lowest: compound 4; then compound 2; then compound 3. At a limit, above all of these: compound 1.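

In this assay the exchange on a carbon with a double bond to nitrogen brings a 39-fold lower number from compound 3 to compound 4 (1.60 log units; beyond the scatter) and is thus a large step, made by replacing a whole ring rather than by adding one group to it. Among the compounds shown here, the one earlier step at this ring rested on a limit, the value of compound 1, whereas this step joins two true numbers, so its full size can be read. It also shows that this place accepts a larger ring of carbon only, and that a methoxy on that ring, alongside the hydroxy, does not stop the number from falling.

Because the ring, the hydroxy and the methoxy all change in this single step, the compounds shown leave open which of them carries the drop, and whether an amine, an ethoxy or a carboxylic acid in place of the hydroxy or the methoxy would give a similar number. Nothing measured here bears on why this exchange has so large an effect.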